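The source may report more compounds than this note shows. Statements on the series, on what has been measured and on what is new or still open speak of the compounds shown alone.

The three measured compounds share one core, carrying a sulfonamide at each end. Compound 1 `O=S(=O)(Nc1ccc2oc(-c3ccc(NS(=O)(=O)c4cccc5nonc45)cc3)nc2c1)c1ccc(Cl)s1` pairs a chlorinated thiophene sulfonyl on one side with a bicyclic heteroaromatic sulfonyl on the other. Compound 2 `O=S(=O)(Nc1ccc(-c2nc3cc(NS(=O)(=O)c4ccccc4)ccc3o2)cc1)c1ccccc1` carries a plain benzene sulfonyl at both ends, and compound 3 `O=S(=O)(Nc1ccc(-c2nc3cc(NS(=O)(=O)c4ccccc4O)ccc3o2)cc1)c1ccccc1O` carries a hydroxylated benzene sulfonyl at both ends.

In an assay on cells for inhibition of HSP60/HSP10 (Homo sapiens), with a stated time of 60 min (on this read-out higher numbers stand for weaker inhibition and lower numbers for stronger inhibition), compound 1 gives 13000 nM. Compound 2 gives 80000 nM in this assay, and compound 3 gives 18000 nM. Compound 1 thus holds the lowest number of the three; its gap to compound 3 lies within the scatter, while its gap to compound 2 lies beyond it.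

Compound 4 `CS(=O)(=O)Nc1ccc(-c2nc3cc(NS(=O)(=O)c4ccc(Cl)s4)ccc3o2)cc1` keeps the chlorinated thiophene sulfonyl of compound 1 and differs from it in this way: one carbon atom in place of a group of 9 heavy atoms (6 carbon, 2 nitrogen, 1 oxygen; one five-membered aromatic ring with 3 hetero atoms, one six-membered aromatic ring of carbon only), on a sulfonyl sulfur. For the measured compounds named here, no measured pair shows a change of this kind, so the size of the step rests on the structural picture alone. Replacing a nine-atom bicyclic aromatic sulfonyl with a single methyl removes a large part of one end of the molecule, and a weaker inhibition is expected, a step of a 2.3-fold higher number from compound 1 to compound 4 (0.36 log units; beyond the scatter) in this assay. For compound 4 the estimated value is 30000 nM, with a range from 10000 nM to 100000 nM.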

Compound 4, half-maximal inhibitory concentration: 43000 nM
Compound 4: the middle estimate sits 1.4-fold (0.16 log units) below what was measured; measured number inside the range.
By their numbers in this assay, from the lowest: compounds 1 and 3 (each within the scatter of the next); then compounds 4 and 2 (each within the scatter of the next).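

In this assay, putting a methyl on the sulfonyl sulfur in place of the bicyclic group gives a 3.3-fold higher number from compound 1 to compound 4 (0.52 log units; beyond the scatter), a step beyond the usual scatter. This is the first pair shown that differs in only one place, so the change in the number can be tied to this one end of the molecule, with the chlorinated thiophene sulfonyl and the shared core left as they were. What sits on this sulfonyl sulfur therefore matters for the read-out, but nothing measured here explains why the number moves in this way.

The pair has only two end points, a large bicyclic group and a single carbon, so it leaves open how much of the larger group is needed and whether a propyl chain, a piperidine ring or a carboxylic acid on this sulfur would bring the number back down. It also leaves open whether the chlorinated thiophene sulfonyl at the other end of the molecule responds as strongly to the same kind of replacement.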